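A few compounds are considered here, and "the series" means these few. Any claim that something is new, unique, unknown or untested is made for them only; others in the source may bear on it.

Compound 1 `NC(=O)c1ccn(-c2cccc(OC(=O)NCCCCCCc3ccccc3)c2)c1` and compound 2 `NC(=O)c1ccn(-c2cccc(OC(=O)NCCOCCOc3ccccc3)c2)c1` share one core and differ only in the chain that hangs from the carbamate. In an assay (brain) for inhibition of Fatty-acid amide hydrolase 1 (Mus musculus), with stated times of 20 min and 15 min (on this read-out higher numbers stand for weaker inhibition and lower numbers for stronger inhibition), compound 1 gives 0.6 nM, while compound 2 gives 87 nM; the change between them is a 150-fold higher number from compound 1 to compound 2 (2.16 log units; beyond the scatter). Going by the values given here, compound 2 therefore stands at the higher of the two numbers, with compound 1 as its only neighbour. Compound 3 `NC(=O)c1ccn(-c2cccc(OC(=O)NCCOCCOc3c(F)cc(F)cc3F)c2)c1` keeps the whole chain of compound 2 and alters only its far end: 2,4,6-trifluorophenyl in place of phenyl on an oxygen on a saturated carbon. Among the compounds with values here, no measured step touches that ring. Within the data shown here, the single step, a 150-fold higher number from compound 1 to compound 2 (2.16 log units; beyond the scatter), concerns the chain itself and says nothing about fluorine on the terminal ring. With nothing to point either way, the expectation for compound 3 in this assay is a step no larger than the scatter, a 1.1-fold lower number from compound 2 to compound 3 (0.04 log units; within the scatter). Compound 3 is thus estimated at 80 nM, between 25 nM and 250 nM.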

Compound 3, half-maximal inhibitory concentration: 43 nM
Beside the measured number, compound 3's estimate is 1.9-fold (0.27 log units) above it; measured number inside the range.
By their numbers in this assay, from the lowest: compound 1; then compound 3; then compound 2.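

The far end of the chain is not silent: in this assay, 2,4,6-trifluorophenyl in place of phenyl on the oxygen gives a 2.0-fold lower number from compound 2 to compound 3 (0.31 log units; beyond the scatter) and so only just clears the usual scatter. This ring can therefore move the number, although this modest step is much smaller than the step from changing the chain itself, a 150-fold higher number from compound 1 to compound 2 (2.16 log units; beyond the scatter) in the same assay. Nothing measured here bears on why the trifluorinated ring gives the lower number.

As far as these compounds go, it remains open whether a single fluorine on the ring would give a similar step, or whether a chlorine or a methoxy group would. Also unknown are the effect of the same ring change on the chain of compound 1 and of an amine or a carboxylic acid in place of the ring.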